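Opening the Ring of an Inactive Compound

This account rests on a few compounds, and the source may have more. Where it says the series, first, only, none or still open, it means among the compounds named here.

In a functional assay on HO8910 cells (Homo sapiens) for inhibition, read by MTT assay, with a stated time of 24 h, tested at 100 ug/mL (on this read-out lower numbers stand for less inhibition of growth and higher numbers for more inhibition of growth at the one concentration tested), compound 1 (`O=C(CCCCC(S)CCS)NO`) gives 49.3% and compound 2 (`O=C(CCCCC1CCSS1)Nc1ccc(Cl)cn1`) gives 68.6%. Compound 3 (`O=C(CCCCC1CCSS1)Nc1cccc2ccccc12`) is reported as "not active" (no number reported), with no number, which leaves no exact starting value for the next step.

Compound 4 (`O=C(CCCCC(S)CCS)Nc1cccc2ccccc12`) keeps the rest of compound 3 and changes one place: a group of 5 heavy atoms (3 carbon, 2 sulfur; no ring) in place of a group of 5 heavy atoms (3 carbon, 2 sulfur; one five-membered non-aromatic ring with 2 hetero atoms), on a saturated chain carbon, four bonds along the chain from a carbonyl carbon. The ring is thus replaced by an open chain of the same size, carrying the same sulfur atoms.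

Among the compounds with values here, no measured pair shows this change alone. Compound 1 has the same open group and gives 49.3%, but it also differs from compound 4 elsewhere, so it is only a loose guide. A modest gain in growth inhibition over compound 3 is expected in this assay, although compound 4 could also prove inactive. For compound 4, the estimated growth inhibition is 22%, with an expected range from 3% to 48%.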

Compound 4, percent growth inhibition at one concentration: "not active" (no number reported)
Compound 4: no number reported; the estimate stays without a comparison.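

In this assay compound 3 and compound 4 are both reported as not active, without a number, so no step can be read between them. No other data here bear on this result. From the compounds shown here alone, whether the open 1,3-disulfanylpropyl group changes growth inhibition at all stays open.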